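Urea in Place of Hydroxyacetamide on a Shared Side Chain

A few compounds are considered here, and "the series" means these few. Any claim that something is new, unique, unknown or untested is made for them only; others in the source may bear on it.

Of the compounds shown here, three have been measured in an assay for inhibition of acyl-CoA desaturase 1 (Rattus norvegicus), using microsomes; a higher number here means a weaker inhibitor, a lower number a stronger inhibitor. Compound 1 `CC1(C)Oc2ccc(NCc3ccc(Cl)c(Cl)c3)cc2N(CCNC(=O)CO)C1=O` gives 12 nM, compound 2 `CC(C)c1nc2ccc(NCc3cccc(C(F)(F)F)c3)cc2n(CCNC(=O)CO)c1=O` gives 2800 nM, and compound 3 `Cc1nc2ccc(NCc3cccc(C(F)(F)F)c3)cc2n(CCNC(=O)[C@@H](C)O)c1=O` gives 3900 nM. Compound 3 therefore carries the highest of the three numbers; its gap to compound 2 lies within the scatter, whereas its gap to compound 1 lies far beyond it. Compound 4 `Cc1nc2ccc(NCc3cccc(C(F)(F)F)c3)cc2n(CCNC(N)=O)c1=O` has not yet been measured. It differs from compound 3 by amino in place of 1-hydroxyethyl on a carbonyl carbon. Among the measured compounds shown here, no measured pair shows this change, so its size is unknown from these data. The step of a 1.3-fold higher number from compound 3 to compound 4 (0.11 log units; within the scatter) is expected to be small, with no change beyond the scatter or a modest rise in this assay. Compound 4 is expected to give 5000 nM, within a range from 1500 nM to 15000 nM.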

Compound 4, half-maximal inhibitory concentration: 15 nM
For compound 4 the middle estimate is 330-fold (2.52 log units) above the measured one, outside the stated range (below it).
By their numbers in this assay, from the lowest: compounds 1 and 4 (each within the scatter of the next); then compounds 2 and 3 (each within the scatter of the next).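

With amino in place of 1-hydroxyethyl on a carbonyl carbon, this assay shows a 260-fold lower number from compound 3 to compound 4 (2.41 log units; beyond the scatter). Among the compounds shown here, this is the first measured pair that differs in one place, and it shows that this side chain position, where ((1-hydroxyethyl)carbonyl)amino becomes ureido, can carry a large change in the read-out. No information is available to explain the size of this step.

Still open, from the compounds shown here alone, is whether a methylamino or dimethylamino group on the same carbonyl carbon would keep this low number. Going by these compounds, it is also open whether ureido would give a step of similar size on the core of compound 2.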